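The source may report more compounds than this note shows. Statements on the series, on what has been measured and on what is new or still open speak of the compounds shown alone.

In a functional assay on MDA-MB-453 cells (Homo sapiens) for cytotoxicity, read by MTT assay, with a stated time of 48 h (on this read-out higher numbers stand for weaker inhibition and lower numbers for stronger inhibition), three compounds have results so far. Compound 1 (`COc1cc(C#N)ccc1OCc1nnc(-c2ccc(C)cc2)o1`) gives 38400 nM and compound 3 (`COc1ccc(-c2nnc(COc3ccc(C#N)c(F)c3)o2)cc1`) gives 45500 nM so these two sit within the usual scatter of each other. Compound 2 (`N#Cc1ccc(OCc2nnc(-c3ccccc3)o2)cc1F`) reports only a limit of the assay (> 50000 nM). Compound 4 (`Cc1ccc(-c2nnc(COc3ccc(C#N)c(F)c3)o2)cc1`) is not yet measured and differs from compound 3 by methyl in place of methoxy on an aromatic carbon. Within the data shown here, the one measured step at that place (an at least 1.0-fold lower number from compound 2 to compound 3 (0.04 log units; that floor lies within the scatter)) put methoxy in place of hydrogen and stayed within the scatter. Compound 1 also carries 4-methylphenyl, though it differs elsewhere, and its value of 38400 nM offers a rough guide. No change beyond the scatter is therefore expected (a 1.1-fold lower number from compound 3 to compound 4 (0.03 log units; within the scatter)). The estimate for compound 4 is 42000 nM with an expected range from 21000 nM to 70000 nM in this read-out.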

Compound 4, half-maximal inhibitory concentration: > 50000 nM
Compound 4: only a limit was reported (the forecaster's own chance of this, stated with the estimate: 35%); at least 1.1-fold (0.07 log units) between middle value and limit.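

Methyl in place of methoxy gives an at least 1.0-fold higher number from compound 3 to compound 4 (0.04 log units; that floor lies within the scatter) in this assay, and this is only a floor, so the true size of the change stays unknown. This place on the ring has now carried hydrogen, methoxy and methyl, and no readable step at it goes beyond the scatter. Compound 2 and compound 4 each report only a limit, so the step between them cannot be read: the limit of > 50000 nM in this assay, at which 2 of the 4 values shown sit.

Still open, going by these compounds, is whether an amine or a carboxylic acid at this place would give a clearly lower number. Also open, on these data alone, is how far compound 4 really lies from compound 3.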